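The source may report more compounds than this note shows. Statements on the series, on what has been measured and on what is new or still open speak of the compounds shown alone.

Working notes on the series, all read in an ADME assay (liver) for metabolic stability, with Liver microsome (Rattus norvegicus) as the target, using microsomes and NADPH, with a stated time of 30 min, tested at 1 uM; a lower number here means slower removal, a higher number faster removal of the compound. Of the compounds shown here, two have numbers so far. Compound 1 (`Nc1ccc(S(=O)(=O)N2CCN(c3ncc(C(O)(C(F)(F)F)C(F)(F)F)cc3C#CCCO)CC2)cn1`) gives 68 mL.min-1.g-1, and compound 2 (`Nc1ccc(S(=O)(=O)N2CCN(c3ncc(C(O)(C(F)(F)F)C(F)(F)F)cc3-c3ccc4sccc4c3)CC2)cn1`) gives 487 mL.min-1.g-1, the higher of the two. Among the compounds with values here, the only measured step is a 7.2-fold higher number from compound 1 to compound 2 (0.86 log units; beyond the scatter), with 1-benzothiophen-5-yl in place of 4-hydroxybut-1-yn-1-yl on an aromatic carbon.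

Next is compound 3 (`Nc1ccc(S(=O)(=O)N2CCN(c3ncc(C(O)(C(F)(F)F)C(F)(F)F)cc3-c3cccc4[nH]ncc34)CC2)cn1`), which carries 1H-indazol-4-yl in place of 1-benzothiophen-5-yl at the same place, ortho to a large group and two atoms from the ring nitrogen: 1H-indazol-4-yl in place of 1-benzothiophen-5-yl on an aromatic carbon. The measured step bears on this only indirectly, since it replaced a chain with a two-ring group, whereas here one two-ring group replaces another. Within the data shown here, no measured pair tests this exchange directly. The size of a 7.2-fold higher number from compound 1 to compound 2 (0.86 log units; beyond the scatter) therefore serves as a rough ceiling, and a smaller step is expected. Among the measured compounds shown here, with compound 2 at 487 mL.min-1.g-1, the top of the numbers so far, the expected direction is downward, with wide uncertainty. The estimated change is a 2.2-fold lower number from compound 2 to compound 3 (0.35 log units; beyond the scatter). For compound 3 the expected value is 220 mL.min-1.g-1, with an estimated range of 90 mL.min-1.g-1 to 500 mL.min-1.g-1.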

Compound 3, intrinsic clearance in microsomes: 93 mL.min-1.g-1
Beside the measured number, compound 3's estimate is 2.4-fold (0.37 log units) above it; measured number inside the range.
By their numbers in this assay, from the lowest: compounds 1 and 3 (each within the scatter of the next); then compound 2.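

At this place on the six-membered aromatic ring, ortho to a large group, the two-ring groups do not read alike in this assay: 1H-indazol-4-yl in place of 1-benzothiophen-5-yl, with the same count of heavy atoms, gives a 5.2-fold lower number from compound 2 to compound 3 (0.72 log units; beyond the scatter), so the high number of compound 2 does not follow from a two-ring group as such. The exchange swaps the sulfur for two nitrogens and adds a hydrogen-bond donor, and 1H-indazol-4-yl in place of 4-hydroxybut-1-yn-1-yl gives a 1.4-fold higher number from compound 1 to compound 3 (0.14 log units; within the scatter), leaving a two-ring group and a chain within the scatter of each other. Nothing measured here bears on why these steps come out as they do.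

Open, from the compounds shown here alone, is which part of the exchange carries the step, the sulfur, the ring nitrogens or the hydrogen-bond donor, since all of these change together between the two compounds. A 1-methyl-1H-indazol-4-yl group or a 1H-indol-4-yl group at this place would separate them, and a single phenyl ring would show how much depends on the second ring.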